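Ethyl on the Ring Nitrogen and Tolerated Concentration

The source may report more compounds than this note shows. Statements on the series, on what has been measured and on what is new or still open speak of the compounds shown alone.

In an ADME assay on HEL cells (Homo sapiens) for cytotoxicity, read by microscopy (a higher number here means that more compound is tolerated, a lower number that less compound is tolerated), compound 1 `Cc1cc(O)c(C(c2cn([C@H]3C[C@H](O)[C@@H](CO)O3)c(=O)[nH]c2=O)c2c(O)cc(C)oc2=O)c(=O)o1` gives only a limit, > 100000 nM. Compound 3 `Cc1cc(O)c(C(c2cn([C@H]3C[C@H](O)[C@@H](CO)O3)c(=O)[nH]c2=O)c2c(O)cc(C)[nH]c2=O)c(=O)[nH]1` likewise reaches only a limit in this assay, > 100000 nM. Compound 2 `Cc1cc2c(c(=O)[nH]1)C(c1cn([C@H]3C[C@H](O)[C@@H](CO)O3)c(=O)[nH]c1=O)C(C#N)=C(N)O2` stands in the same place: in this assay compound 2 gives a limit as well, > 100000 nM. Among the compounds with values here, all three values thus sit at the limit of > 100000 nM in this assay, at which 3 of the 3 values shown sit, and no step between measured compounds can be sized. Compound 4 `CCn1c(C)cc2c(c1=O)C(c1cn([C@H]3C[C@H](O)[C@@H](CO)O3)c(=O)[nH]c1=O)C(C#N)=C(N)O2` differs from compound 2 by ethyl in place of hydrogen on an aromatic nitrogen. With every measured value at the limit, the step expected in this assay is a number no higher from compound 2 to compound 4 (the limit leaves the size open), none beyond the scatter. Compound 4 is therefore estimated at 100000 nM, with a range from 50000 nM to 200000 nM, and most likely reported again only as a limit.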

Compound 4, minimum cytotoxic concentration: > 100000 nM
Compound 4 was reported as a limit; the forecaster's own chance of this, stated with the estimate: 85%; the middle value lies on the limit itself.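

Compound 4, like compound 2, gives only a limit in this assay, so no step between them can be read: the limit of > 100000 nM in this assay, at which 4 of the 4 values shown sit.

The compounds shown leave open whether ethyl in place of hydrogen on an aromatic nitrogen changes the tolerated concentration at all.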